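The source may report more compounds than this note shows. Statements on the series, on what has been measured and on what is new or still open speak of the compounds shown alone.

Compounds measured in an ADME assay on microsomes from liver (Homo sapiens) for metabolic stability, read by LC-MS, using NADPH, with a stated time of 10 min, tested at 10 uM; a lower number here means that the compound disappears faster, a higher number that the compound lasts longer: compound 1 `CO[C@H]1CC[C@H](n2nc(Oc3cc(C(F)(F)F)ccn3)c3c(N)ncnc32)CC1` gives > 2.41 h, which is a limit of the assay and not a number (the limit of > 2.41 h in this assay, at which 1 of the 3 values shown sits). Compound 2 `Nc1ncnc2c1c(Oc1cc(C(F)(F)F)ccn1)nn2[C@H]1C[C@H](F)C1` gives 2.03 h. Compound 3 `Nc1ncnc2c1c(Oc1cc(C(F)(F)F)ccn1)nn2C1CCCC1` gives 0.333 h.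

Of the two plain numbers, compound 2 stands highest; its nearest neighbour is compound 3, with a 6.1-fold lower number from compound 2 to compound 3 (0.79 log units; beyond the scatter). The value of compound 1 is a limit, so compound 1 cannot be ranked against the two others. Every measured step changes the group on the aromatic nitrogen: an at least 1.1-fold lower number from compound 1 to compound 2 (0.07 log units; that floor lies within the scatter), an at least 7.2-fold lower number from compound 1 to compound 3 (0.85 log units; beyond the scatter) and the step already quoted. Among the compounds with values here, the group on the six-membered aromatic ring with one nitrogen stays trifluoromethyl in all three measured compounds, so no measured step bears on the change now at hand.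

Compound 4 `Nc1ncnc2c1c(Oc1cc(Cl)ccn1)nn2[C@H]1C[C@H](F)C1` differs from compound 2 in one place: chloro in place of trifluoromethyl on an aromatic carbon. Within the data shown here, with no measured step to lean on, the change is expected to give a step within the scatter, a 1.1-fold lower number from compound 2 to compound 4 (0.05 log units; within the scatter). Compound 4 is therefore estimated at 1.8 h in this assay, with a range from 0.8 h to 3.5 h.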

Compound 4, half-life: 0.833 h
Compound 4: middle estimate off by 2.2-fold (0.33 log units), on the high side; low and high end bracket the measured number.
By their numbers in this assay, from the lowest: compound 3; then compound 4; then compound 2. At a limit, above all of these: compound 1.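

In this assay the place opposite the ring nitrogen proves to matter: chloro in place of trifluoromethyl gives a 2.4-fold lower number from compound 2 to compound 4 (0.39 log units; beyond the scatter), a modest step, whereas all earlier steps changed only the group on the aromatic nitrogen. The half-life therefore answers to both places on the shared core, since the change on the aromatic nitrogen gave a 6.1-fold lower number from compound 2 to compound 3 (0.79 log units; beyond the scatter), which is also modest, and both steps start from compound 2. Nothing measured among these compounds gives a reason for the step from trifluoromethyl to chloro, so it stands as an observation on one pair.

The compounds shown hold this change only with 3-fluorocyclobutyl on the aromatic nitrogen, so it stays open whether chloro gives a like step with cyclopentyl or with 4-methoxycyclohexyl in that place. Also open, as far as these compounds go, is how other groups at this position on the six-membered aromatic ring would stand against trifluoromethyl and chloro, for instance a nitrile, a methoxy group, an amine or a plain hydrogen, and whether any of them would carry the half-life beyond that of compound 2.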